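From Fluoro to Nitro at the Cytotoxicity Limit

This account rests on a few compounds, and the source may have more. Where it says the series, first, only, none or still open, it means among the compounds named here.

The starting point is compound 2 `O=c1ccoc2cc(OCc3cn(Cc4ccc(F)cc4)nn3)ccc12`. In a functional assay on A549 cells (Homo sapiens) for cytotoxicity, read by MTT assay, with a stated time of 48 h (a lower number here means a stronger inhibitor, a higher number a weaker inhibitor), compound 2 gives only a limit of the measurement, > 100000 nM. Its neighbour compound 1 `O=c1ccoc2cc(OCc3cn(Cc4ccccc4)nn3)ccc12` likewise gives only a limit in this assay, > 100000 nM. The step that the two limits leave unreadable from compound 1 to compound 2 between them cannot be read, because of the limit of > 100000 nM in this assay, at which 2 of the 2 values shown sit.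

Compound 3 `O=c1ccoc2cc(OCc3cn(Cc4ccc([N+](=O)[O-])cc4)nn3)ccc12` carries the change (nitro in place of fluoro on an aromatic carbon). Among the compounds with values here, no readable measured step bears on this change: the only step available, from compound 1 to compound 2, is one that its two limits leave unreadable. The step of a number no higher from compound 2 to compound 3 (the limit leaves the size open) is therefore estimated to stay within the scatter, with compound 3 most likely remaining at the limit. In this assay compound 3 is expected to give 100000 nM, within a range from 50000 nM to 300000 nM.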

Compound 3, half-maximal inhibitory concentration: > 100000 nM
Compound 3: a limit, no number; the forecaster's own chance of this, stated with the estimate: 85%; the middle value sits exactly at the limit.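

The steps from compound 2 to compound 3 and from compound 1 to compound 3 cannot be read, because all three compounds give only a limit: the limit of > 100000 nM in this assay, at which 3 of the 3 values shown sit. The compounds shown leave open whether hydrogen, fluoro and nitro at this place differ at all in this assay.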